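Adding a Fluorine to the Pyridine Ether of Compound 2

A few compounds are considered here, and "the series" means these few. Any claim that something is new, unique, unknown or untested is made for them only; others in the source may bear on it.

Compound 1 `Cc1ccc(Oc2ccc3nc(COc4cccc(C(=O)O)c4)n(C)c3n2)cc1F` gives 14.8 10^-6 cm/s in an ADME assay for permeability, using PAMPA, with a stated time of 4 h; on this read-out higher numbers stand for higher permeability and lower numbers for lower permeability.
Compound 2 `Cc1ccc(Oc2ccc3nc(COc4cccc(C(=O)O)c4)n(C)c3c2)nc1` gives 4.8 10^-6 cm/s in this assay.

In this assay compound 2 holds the lower of the two numbers, and the number for compound 1 lies higher by more than the scatter. Compound 3 `Cc1cc(F)cnc1Oc1ccc2nc(COc3cccc(C(=O)O)c3)n(C)c2c1` differs from compound 2 in one place: 5-fluoro-3-methylpyridin-2-yl in place of 5-methylpyridin-2-yl on an oxygen on an aromatic ring. For the measured compounds named here, no measured pair shows what such a change does here, so only a modest step is expected: a 1.4-fold higher number from compound 2 to compound 3 (0.13 log units; within the scatter), a small rise that may not clear the scatter. Compound 3 is therefore expected to give 6.5 10^-6 cm/s, with a range from 3.5 10^-6 cm/s to 12 10^-6 cm/s.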

Compound 3, apparent permeability: 8.3 10^-6 cm/s
Compound 3: the middle estimate sits 1.3-fold (0.11 log units) below what was measured; low and high end bracket the measured number.
By their numbers in this assay, from the lowest: compounds 2, 3 and 1 (each within the scatter of the next, the first and the last beyond it).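

For the compounds shown here, measured in this assay the swap of 5-methylpyridin-2-yl for 5-fluoro-3-methylpyridin-2-yl on the oxygen gives a 1.7-fold higher number from compound 2 to compound 3 (0.24 log units; within the scatter) and is the first one-place step in this set, so this position accepts the larger group without a change beyond the usual spread. Since the swap both adds a fluorine and changes where the methyl sits, this single pair cannot separate the two. Nothing measured here offers an explanation for the result. The compounds shown leave open how this position would respond to a larger difference, such as an amine or a methoxy group on the pyridine in place of the fluorine.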